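The source may report more compounds than this note shows. Statements on the series, on what has been measured and on what is new or still open speak of the compounds shown alone.

Measured so far in an assay on HEK293 cells for inhibition of SCN8A/SCN1B (Homo sapiens), read by patch clamp, with a stated time of 20 min; a lower number here means a stronger inhibitor, a higher number a weaker inhibitor:
Compound 1, `C[C@H](Nc1cc(F)c(S(=O)(=O)Nc2cscn2)cc1Cl)c1ccccc1`, gives 650 nM.
Compound 2, `C[C@H](Nc1cc(F)c(S(=O)(=O)Nc2cscn2)cc1Cl)c1cc(F)ccc1F`, gives 119 nM.

Within the data shown here, of these two numbers compound 2 holds the lower one; its only neighbour is compound 1, and the step between them, a 5.5-fold lower number from compound 1 to compound 2 (0.74 log units; beyond the scatter), lies beyond the scatter. Compound 3, `COc1ccc(F)c([C@H](C)Nc2cc(F)c(S(=O)(=O)Nc3cscn3)cc2Cl)c1`, is the next to be measured in this assay. It differs from compound 2 by methoxy in place of fluoro on an aromatic carbon: a methoxy takes the place of a fluoro on an aromatic carbon of a six-membered aromatic ring of carbon only, meta to a large group and para to a fluoro group, so that the 2,5-difluorophenyl becomes a 2-fluoro-5-methoxyphenyl. Among the measured compounds shown here, no measured step exchanges one substituent for another on this ring. For the measured compounds named here, the single step available, from compound 1 to compound 2, introduced both fluoro groups together, and it gives no direct guide to swapping one of them for a methoxy. The step expected is therefore a 1.3-fold higher number from compound 2 to compound 3 (0.10 log units; within the scatter), one that need not exceed the scatter. The estimate for compound 3 in this assay is 150 nM, within 50 nM to 450 nM.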

Compound 3, half-maximal inhibitory concentration: 110 nM
Compound 3: the middle estimate sits 1.4-fold (0.13 log units) above what was measured, and the stated range covers the measured number.
By their numbers in this assay, from the lowest: compounds 3 and 2 (each within the scatter of the next); then compound 1.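

In this assay the exchange of fluoro for methoxy on this aromatic carbon, meta to a large group and para to a fluoro group, gives a 1.1-fold lower number from compound 2 to compound 3 (0.03 log units; within the scatter) and so leaves the 2-fluoro-5-methoxyphenyl and the 2,5-difluorophenyl indistinguishable here, even though the entering group has two heavy atoms in place of one and brings a hydrogen-bond acceptor. Set against the plain phenyl, the new ring gives a 5.9-fold lower number from compound 1 to compound 3 (0.77 log units; beyond the scatter), which shows that the lower number seen with the difluoro ring does not depend on keeping fluoro at this place. No independent measurement is available that bears on why these two groups behave alike at this position.

The compounds shown leave open how far this position tolerates other groups, such as an ethoxy with its longer chain, a hydroxy or an amine, on the same aromatic carbon. They also leave open what the remaining fluoro group contributes once methoxy stands at this place, as the step from the phenyl ring changes both positions together.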